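The source may report more compounds than this note shows. Statements on the series, on what has been measured and on what is new or still open speak of the compounds shown alone.

The shared core is that of compound 1 `Cc1cc(C)cc(NN=C2CCC(C)n3c2ncc(C(=O)O)c3=O)c1`. In a functional assay on the whole organism with Rattus norvegicus as the target (a lower number here means that less compound is needed, a higher number that more compound is needed for the effect), compound 1 gives > 320 umol/kg, which is a limit of the assay and not a number. Compound 2 `CC1CCC(=NNc2cc(Cl)cc(Cl)c2)c2ncc(C(=O)O)c(=O)n21` carries 3,5-dichlorophenyl in place of 3,5-dimethylphenyl on an amine nitrogen. In this assay compound 2 gives > 100 umol/kg, again a limit. Compound 3 `CC1CCC(=NNc2ccccn2)c2ncc(C(=O)O)c(=O)n21` carries pyridin-2-yl on that amine nitrogen. In this assay compound 3 gives > 100 umol/kg, also a limit, so compound 3 stands only at a limit. Of the three values shown, two sit at the limit of > 100 umol/kg in this assay, at which 2 of the 3 values shown sit, and one at the limit of > 320 umol/kg in this assay, at which 1 of the 3 values shown sits. Hence a step that the two limits leave unreadable from compound 1 to compound 2, a step that the two limits leave unreadable from compound 1 to compound 3 and a step that the two limits leave unreadable from compound 2 to compound 3 are all unreadable.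

Compound 4 `CNN=C1CCC(C)n2c1ncc(C(=O)O)c2=O` differs from compound 3 by methyl in place of pyridin-2-yl on an amine nitrogen. Within the data shown here, no measured step on this amine nitrogen has a readable size, so the expected step that the limit leaves unreadable from compound 3 to compound 4 is set at none beyond the scatter. For compound 4 the estimate in this assay is 300 umol/kg, expected within 100 umol/kg to 3000 umol/kg, most probably again reported only as a limit.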

Compound 4, dose for 50% inhibition: > 100 umol/kg
Compound 4 gave a limit, no number; the forecaster's own chance of this, stated with the estimate: 80%; the middle value lies beyond the limit too.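

In this assay compound 4 gives > 100 umol/kg, a limit and not a number, so its steps from compound 1, compound 2 and compound 3 cannot be read. The compounds shown leave open whether any group on this amine nitrogen gives a readable value in this assay.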